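A Single Substitution at the Amide-Capped End of a Peptidomimetic

This account rests on a few compounds, and the source may have more. Where it says the series, first, only, none or still open, it means among the compounds named here.

Two compounds from this series share a short peptide-like core built from an amide-linked chain ending in a benzylamide. Compound 1 `Cc1ccc(CNC(=O)[C@H](CCc2ccccc2)NC(=O)[C@H](CNC(=O)CC(C)(C)C)NC(=O)CCc2ccccc2)cc1` carries a phenylpropanoyl group at one end; for it an assay on HEK293 cells for inhibition of nuclear factor NF-kappa-B complex (Homo sapiens), read by a luciferase reporter, with stated times of 1 h and 3 h (a higher number here means a weaker inhibitor, a lower number a stronger inhibitor), records "not determined" (no result reported), so it contributes no number. Compound 2 `CC(C)(C)CNC(=O)C[C@H](NC(=O)CN1CCCCC1)C(=O)N[C@@H](CCc1ccccc1)C(=O)NCc1ccccc1` is therefore the only point of reference: in this assay compound 2 gives 62 nM, and with no second value to set against it, nothing can be said about where it stands relative to its neighbours.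

Compound 3 `Cc1cc(C(=O)N[C@@H](CC(=O)NCC(C)(C)C)C(=O)N[C@@H](CCc2ccccc2)C(=O)NCc2ccccc2)no1` differs from compound 2 in one place: 5-methyl-1,2-oxazol-3-yl in place of (piperidin-1-yl)methyl on a carbonyl carbon. Among the measured compounds shown here, no measured pair shows what such a swap does, so the expectation rests on the change alone. A saturated ring attached through a methylene gives way to a small aromatic ring bearing a methyl group, attached directly to the carbonyl. For the measured compounds named here, with no precedent, the step from compound 2 to compound 3 is expected to be modest, a 1.6-fold higher number from compound 2 to compound 3 (0.21 log units; within the scatter), with the range kept wide to reflect the lack of a comparison. Compound 3 is accordingly estimated at 100 nM, between 30 nM and 400 nM.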

Compound 3, half-maximal inhibitory concentration: 9 nM
For compound 3 the middle estimate is 11-fold (1.05 log units) above the measured one; measured number outside the range, below it.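

In this assay, among the compounds shown here, the group on this carbonyl carbon clearly matters: putting 5-methyl-1,2-oxazol-3-yl in place of (piperidin-1-yl)methyl gives a 6.9-fold lower number from compound 2 to compound 3 (0.84 log units; beyond the scatter), the first measured step. Since a lower number here means a stronger inhibitor, the piperidine ring is not required for activity in this pair, and a five-membered aromatic ring with 2 hetero atoms can stand in its place with a real gain. The data at hand contain nothing that explains this step.

On these data alone, what remains open is which part of the swap carries the step, since the ring type, the methyl group and the methylene link all change together in going from compound 2 to compound 3. A plain 1,2-oxazol-3-yl group without the methyl, a phenyl ring attached directly to the carbonyl, or a piperidine ring attached directly to the carbonyl would each separate one of these changes from the others, and none of them is among the compounds shown here.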